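Piperidine-3-carboxamide bis-sulfonamides: oxetanyl amide

A few compounds are considered here, and "the series" means these few. Any claim that something is new, unique, unknown or untested is made for them only; others in the source may bear on it.

Measured in a functional assay on MIA PaCa-2 cells (Homo sapiens) for inhibition, read by MTT assay, with a stated time of 3 days; on this read-out lower numbers stand for stronger inhibition and higher numbers for weaker inhibition:
- compound 1 `CCN(CC)S(=O)(=O)c1ccc(S(=O)(=O)N2CCC[C@@H](C(=O)N[C@@H]3CCN(C(=O)OC(C)(C)C)C3)C2)cc1`: > 10000 nM, a limit of the assay.
- compound 2 `CCN(CC)C(=O)[C@@H]1CCCN(S(=O)(=O)c2ccc(S(=O)(=O)N(CC)CC)cc2)C1`: > 10000 nM, also a limit of the assay.

Compound 2 stands at the upper limit of this assay; (the limit of > 10000 nM in this assay, at which 2 of the 2 values shown sit), so no ranking among the measured compounds is possible from these numbers. Compound 3 `CCN(CC)S(=O)(=O)c1ccc(S(=O)(=O)N2CCC[C@@H](C(=O)NC3COC3)C2)cc1` differs from compound 2 by (oxetan-3-yl)amino in place of diethylamino on a carbonyl carbon. Going by the values given here, no measured step exists for this or any comparable change, so there is nothing to scale an expectation against. The shared core and both sulfonyl groups are retained, and compound 1, which carries a different amide substituent, also sits at the limit. The expected step that the limit leaves unreadable from compound 2 to compound 3 is therefore none beyond the scatter, with a limit result again the most likely outcome. Compound 3 is estimated at 15000 nM, with a range from 4000 nM to 60000 nM.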

Compound 3, half-maximal inhibitory concentration: > 10000 nM
Compound 3: no number, only a limit; the forecaster's own chance of this, stated with the estimate: 80%; the middle value is on the limit's open side.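

No step can be read between compound 1, compound 2 and compound 3, since all three sit at the same limit in this assay: the limit of > 10000 nM in this assay, at which 3 of the 3 values shown sit.

The compounds shown leave open whether any amide substituent on the shared core gives a measurable value in this assay, and how these substituents rank.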